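The source may report more compounds than this note shows. Statements on the series, on what has been measured and on what is new or still open speak of the compounds shown alone.

In a toxicity assay on microsomes from liver (Homo sapiens) for metabolic stability, read by LC-MS, using NADPH, tested at 1 uM (on this read-out lower numbers stand for slow clearance and higher numbers for fast clearance), compound 1 `CCOc1ncc(-c2nc(C(F)(F)F)sc2N2CCN(C(=O)Cn3nc(C)cc3C)[C@H](C)C2)cn1` gives 184 mL.min-1.g-1 as its clearance. Compound 2 `Cc1ncc(-c2nc(C(F)(F)F)sc2N2CCN(C(=O)Cn3nc(C)nc3C)[C@H](C)C2)cn1` reads < 10 mL.min-1.g-1 and that is a limit of the assay, not a number. Compound 3 `Cc1nc(C)n(CC(=O)N2CCN(c3sc(C(F)(F)F)nc3-c3ccc(C(F)(F)F)nc3)C[C@H]2C)n1` differs from compound 2 in one place, where 6-(trifluoromethyl)pyridin-3-yl stands in place of 2-methylpyrimidin-5-yl on an aromatic carbon 6-(trifluoromethyl)pyridin-3-yl in place of 2-methylpyrimidin-5-yl on an aromatic carbon while the rest stays the same. Among the measured compounds shown here, no measured pair shows this swap, so the expected step in this assay is only a cautious guess, a moderate rise an at least 3.0-fold higher number from compound 2 to compound 3 (0.47 log units; beyond the scatter) in clearance. The estimate for compound 3 is 30 mL.min-1.g-1 within an expected range of 11 mL.min-1.g-1 to 90 mL.min-1.g-1 on this read-out.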

Compound 3, intrinsic clearance in microsomes: < 10 mL.min-1.g-1
Compound 3: a limit, no number; the forecaster's own chance of this, stated with the estimate: 20%; middle value at least 3.0-fold (0.47 log units) from the limit.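

In this assay, among the compounds shown here, no step from compound 2 to compound 3 can be read, because both results are limits and not numbers: the limit of < 10 mL.min-1.g-1 in this assay, at which 2 of the 3 values shown sit. As far as these compounds go, whether 6-(trifluoromethyl)pyridin-3-yl in place of 2-methylpyrimidin-5-yl changes clearance at all stays open.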